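Swapping pyrrolidin-2-yl for 4-fluorophenyl

The source may report more compounds than this note shows. Statements on the series, on what has been measured and on what is new or still open speak of the compounds shown alone.

Measured in a functional assay on MDA-MB-231 cells (Homo sapiens) for antiproliferative activity, read by MTT assay, with a stated time of 24 h; on this read-out lower numbers stand for stronger inhibition and higher numbers for weaker inhibition:
- Compound 1 `COc1ccc(-c2noc(-c3ccccc3)n2)cc1OC1CCCC1`: > 1000000 nM, a limit of the assay and not a number
- Compound 2 `COc1ccc(-c2noc(C3CCCN3)n2)cc1OC1CCCC1`: 212000 nM

Among the compounds with values here, compound 2, at 212000 nM, holds the only true number so far. Compound 3 `COc1ccc(-c2noc(-c3ccc(F)cc3)n2)cc1OC1CCCC1` brings one change to it: 4-fluorophenyl in place of pyrrolidin-2-yl on an aromatic carbon. Within the data shown here, the one measured step that bears on this is the near-opposite swap, pyrrolidin-2-yl in place of phenyl, which gave an at least 4.7-fold lower number from compound 1 to compound 2 (0.67 log units; beyond the scatter), beyond the scatter. Returning to an aromatic ring should therefore raise the number, by a similar amount, and the estimated change is a 3.3-fold higher number from compound 2 to compound 3 (0.52 log units; beyond the scatter). Compound 3 is expected at an estimated 700000 nM, within a range of 200000 nM to 2000000 nM.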

Compound 3, half-maximal inhibitory concentration: 55500 nM
For compound 3 the middle estimate is 13-fold (1.10 log units) above the measured one; measured number outside the range, below it.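

Compound 3 shows that an aromatic ring at this position need not do worse than pyrrolidin-2-yl: 4-fluorophenyl gives a 3.8-fold lower number from compound 2 to compound 3 (0.58 log units; beyond the scatter). Compound 1 had suggested the opposite, yet fluoro in place of hydrogen on its phenyl ring gives an at least 18-fold lower number from compound 1 to compound 3 (1.25 log units; beyond the scatter). Compound 1 rests on a limit of the assay and not a number, so that step has no upper end: the limit of > 1000000 nM in this assay, at which 1 of the 3 values shown sits.

Still open, going by these compounds, is whether this gain is particular to fluoro or would also come with another group on the phenyl ring, such as chloro or methoxy. Also open, on these data alone, is how an open-chain amine would compare with pyrrolidin-2-yl here.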